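Carboxy on the Core of Compound 1: Expected Gain

A few compounds are considered here, and "the series" means these few. Any claim that something is new, unique, unknown or untested is made for them only; others in the source may bear on it.

Compound 1 `O=c1[nH]c2ccccc2oc1=O` is the plain parent of this small set. In a functional assay with Rattus norvegicus as the target (a lower number here means a stronger inhibitor, a higher number a weaker inhibitor), compound 1 gives 42000 nM, the highest of the three numbers recorded; its nearest neighbour is compound 2 `COc1cccc2[nH]c(=O)c(=O)oc12`, which gives 7000 nM, and the furthest is compound 3 `O=c1[nH]c2cc([N+](=O)[O-])ccc2oc1=O`, which gives 800 nM. Both substituted compounds therefore inhibit more strongly than the parent. The step of a 6.0-fold lower number from compound 1 to compound 2 (0.78 log units; beyond the scatter) is modest, while the step of a 53-fold lower number from compound 1 to compound 3 (1.72 log units; beyond the scatter) is large.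

Compound 4 `O=C(O)c1ccc2[nH]c(=O)c(=O)oc2c1` has not yet been measured in this assay. It differs from compound 1 in one place: carboxy in place of hydrogen on an aromatic carbon. Both measured steps from compound 1 bear on this change, since each adds a group on the same aromatic carbon ring of the core and each lowers the number beyond the scatter, one by a modest and one by a large amount. A lowering is therefore expected for compound 4 as well, of a size between those two, as an 8.4-fold lower number from compound 1 to compound 4 (0.92 log units; beyond the scatter). Compound 4 is estimated at 5000 nM, with a range from 1500 nM to 20000 nM.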

Compound 4, half-maximal inhibitory concentration: 16000 nM
Compound 4: middle estimate off by 3.2-fold (0.51 log units), on the low side; the range from low to high includes it.
By their numbers in this assay, from the lowest: compound 3; then compound 2; then compound 4; then compound 1.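

In this assay, carboxy in place of hydrogen on this aromatic carbon, meta to a fused ring and para to a fused ring, still lowers the number (a 2.6-fold lower number from compound 1 to compound 4 (0.42 log units; beyond the scatter)), so a third group on the aromatic carbon ring of the core of compound 1 moves the result in the same direction as methoxy and nitro. The size of this step is only modest, which shows that the large gain seen with nitro in compound 3 (800 nM) does not come with every added group. Nothing in hand accounts for the size of this step.

The compounds shown leave open whether an amine or a methyl ester on this same carbon would lower the number further. They also leave open how carboxy would fare on the other carbons of that ring.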